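Fluorine Loss and a Benzamido Group at Compound 4

The source may report more compounds than this note shows. Statements on the series, on what has been measured and on what is new or still open speak of the compounds shown alone.

Values in a functional assay on A549 cells (Homo sapiens) for antiproliferative activity, read by MTT assay; a higher number here means a weaker inhibitor, a lower number a stronger inhibitor:
Compound 1 `COc1cc2c(Oc3ccc(NC(=O)Nc4ccccc4)cc3)ccnc2cc1OCCCCCCC(=O)NO`: 1650 nM
Compound 2 `COc1cc2c(Oc3ccc(NC(=O)N/N=C/c4ccccc4)cc3)ccnc2cc1OCCCCCCC(=O)NO`: 3700 nM
Compound 3 `COc1cc2c(Oc3ccc(NC(=O)N/N=C/c4ccccc4F)cc3)ccnc2cc1OCCCCCCC(=O)NO`: 7780 nM
Compound 4 `COc1cc2c(Oc3ccc(NC(=O)NNC(=O)c4ccccc4)cc3)ccnc2cc1OCCCCCCC(=O)NO`: not yet measured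

Compound 3 has the highest number of the three, making it the weakest so far. The next change is a group of 9 heavy atoms (7 carbon, 1 nitrogen, 1 oxygen; one six-membered aromatic ring of carbon only) in place of a group of 9 heavy atoms (7 carbon, 1 nitrogen, 1 fluorine; one six-membered aromatic ring of carbon only), on an amide-type nitrogen. Within the data shown here, three measured steps bear on it, all modest: a 2.2-fold higher number from compound 1 to compound 2 (0.35 log units; beyond the scatter), a 4.7-fold higher number from compound 1 to compound 3 (0.67 log units; beyond the scatter) and a 2.1-fold higher number from compound 2 to compound 3 (0.32 log units; beyond the scatter). The last adds fluoro alone, and the entering benzamido group has no fluorine. Among the measured compounds shown here, no measured compound carries benzamido, so the comparison is only partial. A modest move toward a lower number in this assay is therefore expected, as the estimated step of a 1.9-fold lower number from compound 3 to compound 4 (0.29 log units; within the scatter). Compound 4 is estimated at 4000 nM, with an expected range from 1600 nM to 9500 nM.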

Compound 4, half-maximal inhibitory concentration: 2820 nM
The estimate for compound 4 lay 1.4-fold (0.15 log units) above the measured number; the range from low to high includes it.
By their numbers in this assay, from the lowest: compounds 1, 4 and 2 (each within the scatter of the next, the first and the last beyond it); then compound 3.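

In this assay benzamido on this amide-type nitrogen gives a 2.8-fold lower number from compound 3 to compound 4 (0.44 log units; beyond the scatter), so this place accepts a group with a carbonyl and the amide hydrogen without the number reaching that of the fluorinated group. The steps of a 1.3-fold lower number from compound 2 to compound 4 (0.12 log units; within the scatter) and a 1.7-fold higher number from compound 1 to compound 4 (0.23 log units; within the scatter) both lie within the scatter, so benzamido cannot be separated from either of those groups here. No measurement shown accounts for these steps.

From the compounds shown here alone, whether fluoro, methoxy or an amine on the aromatic ring of benzamido would shift the number remains open.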